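The source may report more compounds than this note shows. Statements on the series, on what has been measured and on what is new or still open speak of the compounds shown alone.

In an ADME assay on microsomes from liver (Homo sapiens) for metabolic stability, read by LC-MS, using NADPH, tested at 1 uM (on this read-out lower numbers stand for a shorter-lived compound and higher numbers for a longer-lived compound), compound 1 `N#Cc1cnc(NC(=O)CCCOc2ccccc2)s1` gives 0.15 h, the lowest of the two numbers in hand. Among the compounds with values here, the only other measured member, compound 2 `N#Cc1cnc(NC(=O)CCCOc2cccc(C(F)(F)F)c2)s1`, gives 1.33 h; the step of an 8.9-fold higher number from compound 1 to compound 2 (0.95 log units; beyond the scatter) arose from a trifluoromethyl in place of hydrogen on an aromatic carbon. Compound 3 `O=C(CCCOc1ccccc1)Nc1ncc(Cl)s1` is not yet measured and differs from compound 1 by a change on the shared core: chloro in place of cyano on an aromatic carbon. Within the data shown here, no measured step alters the group on the five-membered aromatic ring, so the step from compound 1 to compound 2 does not bear directly on this exchange; it shows only that this assay can move well beyond the scatter. Among the measured compounds shown here, with no precedent for a change at this carbon, the working expectation is a step within the scatter, in either direction. For compound 3 the expected value is 0.2 h, with a range of 0.08 h to 0.5 h, which as a step means an expected 1.3-fold higher number from compound 1 to compound 3 (0.12 log units; within the scatter), not beyond the usual scatter.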

Compound 3, half-life: 0.317 h
Compound 3: the middle estimate sits 1.6-fold (0.20 log units) below what was measured, within the range that was stated.
By their numbers in this assay, from the lowest: compound 1; then compound 3; then compound 2.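

The carbon next to the ring sulfur is not a silent place on the shared core: in this assay, chloro in place of cyano gives a step beyond the scatter (a 2.1-fold higher number from compound 1 to compound 3 (0.32 log units; beyond the scatter)). Together with an 8.9-fold higher number from compound 1 to compound 2 (0.95 log units; beyond the scatter), this means that two separate places in the series have now each moved the half-life beyond the scatter, one of them on the shared core. Compound 3 has neither the triple bond nor the hydrogen-bond acceptor of the cyano group, yet its half-life is the longer of this pair, so neither feature is needed for the higher number here, although no measurement at hand accounts for the step.

As far as these compounds go, whether chloro gives a similar rise with the trifluoromethyl of compound 2 in place remains open, so nothing yet shows how the two changes combine. Also open, from the compounds shown here alone, is how the half-life would respond to other groups on this carbon, such as methyl, bromo or an amine, and to a longer chain between the amide carbonyl and the ether oxygen.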